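The source may report more compounds than this note shows. Statements on the series, on what has been measured and on what is new or still open speak of the compounds shown alone.

Measured compounds:
Compound 1 `CN(C)c1ccc(C(=O)NC(CCCCCC(=O)NO)C(=O)NCc2ccccc2)cc1`, 870 nM
Compound 2 `O=C(CCCCCC(NC(=O)c1ccco1)C(=O)NCc1ccccc1)NO`, 4600 nM
Compound 3 `CC(C)CCNC(=O)C(CCCCCC(=O)NO)NC(=O)c1ccco1`, 4400 nM

All three were tested in a functional assay on NFF cells (Homo sapiens) for antiproliferative activity; a lower number here means a stronger inhibitor, a higher number a weaker inhibitor. Compound 2 gives the highest number of the three. Its nearest neighbour is compound 3, and the two differ only within the scatter. Among the measured compounds shown here, compound 1 is furthest from it: the step of a 5.3-fold higher number from compound 1 to compound 2 (0.72 log units; beyond the scatter) lies beyond the scatter, and this is the only step that changes the group on the carbonyl carbon.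

Compound 4 `O=C(CCCCCC(NC(=O)c1cccnc1)C(=O)NCc1ccccc1)NO` has not yet been measured. It differs from compound 2 in one place: pyridin-3-yl in place of furan-2-yl on a carbonyl carbon. The step of a 1.0-fold lower number from compound 2 to compound 3 (0.02 log units; within the scatter) concerns a different position and says nothing about this change. For the measured compounds named here, the step of a 5.3-fold higher number from compound 1 to compound 2 (0.72 log units; beyond the scatter) shows that exchanging the aromatic group on this carbonyl carbon can shift the number well beyond the scatter, but the data hold no example of pyridin-3-yl at this position, so the direction cannot be read off directly.

Since the change keeps the aromatic ring on the carbonyl carbon and only the ring type changes, a modest move is expected rather than a large one. Compound 4 is therefore estimated at 2500 nM, with a range from 900 nM to 7000 nM, which would correspond to an expected step of a 1.8-fold lower number from compound 2 to compound 4 (0.26 log units; within the scatter).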

Compound 4, half-maximal inhibitory concentration: 24000 nM
For compound 4 the middle estimate is 9.6-fold (0.98 log units) below the measured one; measured number outside the range, above it.
By their numbers in this assay, from the lowest: compound 1; then compounds 3 and 2 (each within the scatter of the next); then compound 4.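

In this assay this position on the carbonyl carbon proves sensitive even to an exchange of one aromatic ring with a single hetero atom for another: a 5.2-fold higher number from compound 2 to compound 4 (0.72 log units; beyond the scatter) is about the same size as a 5.3-fold higher number from compound 1 to compound 2 (0.72 log units; beyond the scatter), which had involved the loss of the 4-(dimethylamino)phenyl group. With the rest of the molecule held constant, the three groups now give a clear order, with 4-(dimethylamino)phenyl lowest, furan-2-yl in the middle and pyridin-3-yl highest, and the whole span, a 28-fold higher number from compound 1 to compound 4 (1.44 log units; beyond the scatter), is large. Furan-2-yl and pyridin-3-yl have the same counts of hydrogen-bond donors and acceptors and neither carries a net charge, and nothing measured here bears on why the number moves.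

As far as these compounds go, it remains open whether plain phenyl, or pyridin-2-yl or pyridin-4-yl, would stand nearer to compound 1 or to compound 4, and whether the dimethylamino group or the phenyl ring matters more in compound 1. Among the compounds shown here, the isobutyl-bearing amide end is seen only with furan-2-yl on the carbonyl carbon, so whether the pyridin-3-yl result carries over to that series is also unknown.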